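Replacing a Tetrazole Ring with a Carbamoyl Group

This account rests on a few compounds, and the source may have more. Where it says the series, first, only, none or still open, it means among the compounds named here.

Measured compounds:
compound 1, `CC(C)C(c1ccc(-c2ccc3cccc(F)c3c2)[nH]c1=O)N1CCNC1=O`: 9.1 nM
compound 2, `CC(C)C(c1noc(=O)[nH]1)c1ccc(-c2ccc3cccc(F)c3c2)[nH]c1=O`: 15 nM
compound 3, `CC(C)C(Cc1nnn[nH]1)c1ccc(-c2ccc3cccc(F)c3c2)[nH]c1=O`: 34 nM

All three share one core and differ only in the group hanging from the side-chain carbon. In an assay on CHO cells for displacement of a labelled ligand from prostaglandin E2 receptor EP3 subtype (Homo sapiens), read by radioligand binding (a lower number here means a stronger inhibitor, a higher number a weaker inhibitor), compound 3 has the highest number of the three: a 3.7-fold higher number from compound 1 to compound 3 (0.57 log units; beyond the scatter) and a 2.3-fold higher number from compound 2 to compound 3 (0.36 log units; beyond the scatter), both modest, while a 1.6-fold higher number from compound 1 to compound 2 (0.22 log units; within the scatter). Compound 4, `CC(C)C(CC(N)=O)c1ccc(-c2ccc3cccc(F)c3c2)[nH]c1=O`, is not yet measured; it differs from compound 3 by carbamoyl in place of 1H-tetrazol-5-yl on a saturated chain carbon, two bonds along the chain from an aromatic carbon. The measured steps show that changing this group shifts the number only modestly, in either direction. Compound 4 is therefore expected to land near compound 3, perhaps slightly weaker: a 1.8-fold higher number from compound 3 to compound 4 (0.25 log units; within the scatter) is the estimated step. The estimate for compound 4 is 60 nM, within 20 nM to 180 nM.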

Compound 4, inhibition constant in the prostaglandin E2 receptor EP3 subtype assay: 5 nM
For compound 4 the middle estimate is 12-fold (1.08 log units) above the measured one; the measured number lies below the stated range.
By their numbers in the prostaglandin E2 receptor EP3 subtype assay, from the lowest: compounds 4, 1 and 2 (each within the scatter of the next, the first and the last beyond it); then compound 3.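

The open carbamoyl group, with no ring, beats both five-membered aromatic rings at this position, so neither ring is needed for binding: in the prostaglandin E2 receptor EP3 subtype assay there is a 6.8-fold lower number from compound 3 to compound 4 (0.83 log units; beyond the scatter) and a 3.0-fold lower number from compound 2 to compound 4 (0.48 log units; beyond the scatter). Against the non-aromatic ring, no order can be given: in the prostaglandin E2 receptor EP3 subtype assay there is a 1.8-fold lower number from compound 1 to compound 4 (0.26 log units; within the scatter). The gain has a price, since in a physicochemical assay for solubility, measured as kinetic solubility, at pH 2 (on this read-out higher numbers stand for higher solubility and lower numbers for lower solubility), compound 3 gives 28000 nM and compound 4 gives 3120 nM, and the swap lowers solubility: the measured solubility of compound 3, 28000 nM, and of compound 4, 3120 nM, a 9.0-fold lower number (0.95 log units; beyond the scatter)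

On these data alone, whether a carboxylic acid or a longer chain ending in carbamoyl would keep the binding while recovering solubility remains open.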